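Pyridyl replacement at the fused core: compound 3 to compound 4

The source may hold more compounds than are shown below. What is called first, only, known or untested is meant among the compounds shown, and "the series" means these compounds.

Compound 3 `CCCN(CCC)c1cc(C)nc2c(-c3ccc(Cl)cn3)c(C)nn12` gives 88 nM in an assay on isolated protein for binding affinity to corticotropin-releasing factor receptor 1 (Homo sapiens) (on this read-out lower numbers stand for stronger inhibition and higher numbers for weaker inhibition), the highest of the three numbers in hand; compound 1 `CCCCN(CCC)c1cc(C)nc2c(-c3ncc(C(F)(F)F)cc3Cl)c(C)nn12` gives 1.2 nM and compound 2 `CCCN(Cc1ccccc1)c1cc(C)nc2c(-c3ncc(C(F)(F)F)cc3Cl)c(C)nn12` gives 1.7 nM. Among the compounds with values here, the only single-point step, a 1.4-fold higher number from compound 1 to compound 2 (0.15 log units; within the scatter), concerns the amine substituent and not the aryl group, so it does not bear on the change in hand. Compound 4 `CCCN(CCC)c1cc(C)nc2c(-c3ncc(N)cc3C)c(C)nn12` differs from compound 3 by 5-amino-3-methylpyridin-2-yl in place of 5-chloropyridin-2-yl on an aromatic carbon. Within the data shown here, compound 1 and compound 2 differ from compound 3 in more than this group, so no measured step isolates it. For compound 4 a modestly lower number is expected, a 2.9-fold lower number from compound 3 to compound 4 (0.47 log units; beyond the scatter), with wide uncertainty. The estimate for compound 4 is 30 nM, in the range 8 nM to 120 nM.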

Compound 4, inhibition constant: 85 nM
Compound 4: middle estimate off by 2.8-fold (0.45 log units), on the low side, within the range that was stated.
By their numbers in this assay, from the lowest: compounds 1 and 2 (each within the scatter of the next); then compounds 4 and 3 (each within the scatter of the next).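

In this assay the step of a 1.0-fold lower number from compound 3 to compound 4 (0.02 log units; within the scatter) lies within the scatter, so at this aromatic carbon of the five-membered aromatic ring, 5-amino-3-methylpyridin-2-yl and 5-chloropyridin-2-yl cannot be told apart. Within the data shown here, this is the first step that changes the pyridyl group alone, with the amine substituent and the shared core held fixed. No data at hand give a reason for this result.

On these data alone, the amino and methyl groups enter together, so their separate contributions remain open. Also open, as far as these compounds go, is what a nitrile or a carboxylic acid in place of that amino group would give.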